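The compounds below may be only part of what the source reports. "The series", "measured", "known", "first", "only" and "open" are said of these compounds alone.

Three compounds share one core and differ only in the aryl group on the nitrogen of the triazole ring. Compound 1 `N#CC1=C(N)Oc2c(N)cc3nc4ccccc4nc3c2C12C(=O)N(Cc1cnnn1-c1ccc(F)cc1)c1ccccc12` carries a 4-fluorophenyl there, and in a functional assay on A549 cells (Homo sapiens) for antiproliferative activity, read by MTT assay, with a stated time of 48 h (a lower number here means a stronger inhibitor, a higher number a weaker inhibitor), compound 1 gives > 50000 nM, which is a limit of the assay rather than a number. Compound 2 `N#CC1=C(N)Oc2c(N)cc3nc4ccccc4nc3c2C12C(=O)N(Cc1cnnn1-c1ccc(Cl)cc1)c1ccccc12` carries a 4-chlorophenyl, and compound 2 likewise gives > 50000 nM, again a limit. Going by the values given here, compound 3 `COc1ccc(OC)c(-n2nncc2CN2C(=O)C3(C(C#N)=C(N)Oc4c(N)cc5nc6ccccc6nc5c43)c3ccccc32)c1` carries a 2,5-dimethoxyphenyl, and compound 3 gives 28100 nM, the only actual number among the three. Because two values sit at the limit of > 50000 nM in this assay, at which 2 of the 3 values shown sit, the step that the two limits leave unreadable from compound 1 to compound 2 cannot be read. The steps of an at least 1.7-fold lower number from compound 1 to compound 3 (0.25 log units; that floor lies within the scatter) and an at least 1.7-fold lower number from compound 2 to compound 3 (0.25 log units; that floor lies within the scatter) show only that the dimethoxyphenyl brought the number inside the measurable range.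

Compound 4 `Cc1cc(C)c(-n2nncc2CN2C(=O)C3(C(C#N)=C(N)Oc4c(N)cc5nc6ccccc6nc5c43)c3ccccc32)c(C)c1` introduces (2,4,6-trimethylphenyl in place of 2,5-dimethoxyphenyl on an aromatic nitrogen). Among the compounds with values here, the measured steps say nothing about a methyl-substituted phenyl, so the expectation rests on the dimethoxyphenyl being the one group with a number. Compound 4 is expected to give 40000 nM, between 15000 nM and 80000 nM. The expected step of a 1.4-fold higher number from compound 3 to compound 4 (0.15 log units; within the scatter) would be toward a weaker inhibitor, with a fair chance of only a limit.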

Compound 4, half-maximal inhibitory concentration: 12700 nM
Estimate against measurement, compound 4: 3.1-fold (0.50 log units) above, and the stated range ends above it.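

In this assay, going by these compounds alone, the change to 2,4,6-trimethylphenyl gives a 2.2-fold lower number from compound 3 to compound 4 (0.34 log units; beyond the scatter) and so, for the first time, two groups on this aromatic nitrogen can be ranked by actual numbers. The entering group has no hydrogen-bond acceptors, unlike 2,5-dimethoxyphenyl, so oxygen on this ring is not required for a measurable value here. Against the halogen-bearing phenyl groups the steps are an at least 3.9-fold lower number from compound 2 to compound 4 (0.59 log units; beyond the scatter) and an at least 3.9-fold lower number from compound 1 to compound 4 (0.59 log units; beyond the scatter) and both are only floors, set by a limit: the limit of > 50000 nM in this assay, at which 2 of the 4 values shown sit.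

The compounds shown do not separate the effect of the number of methyl groups from that of their places on the ring. From the compounds shown here alone, it also remains open how an unsubstituted phenyl, a phenyl bearing an amine or a carboxylic acid, or a plain butyl chain would read on this nitrogen.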